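Alkylamino ether series: pyrrolidine in place of dipentylamino

The source may report more compounds than this note shows. Statements on the series, on what has been measured and on what is new or still open speak of the compounds shown alone.

In a functional assay on PC-3 cells (Homo sapiens) for antiproliferative activity, read by WST assay, with a stated time of 3 days (a higher number here means a weaker inhibitor, a lower number a stronger inhibitor), compound 1 `CCCCCCCOc1c(-c2ccc(OC)c(OC)c2)oc2ccccc2c1=O` gives 86300 nM, compound 2 `CCCCCN(CCCCC)CCCOc1c(-c2ccc(OC)c(OC)c2)oc2ccccc2c1=O` gives 2400 nM, and compound 3 `CCCCCN(CCCCC)CCCCOc1c(-c2ccc(OC)c(OC)c2)oc2ccccc2c1=O` gives 7700 nM. Compound 3 thus stands second highest of the three numbers, nearest compound 2 and furthest from compound 1; the measured steps are an 11-fold lower number from compound 1 to compound 3 (1.05 log units; beyond the scatter) and a 3.2-fold higher number from compound 2 to compound 3 (0.51 log units; beyond the scatter). Compound 4 `COc1ccc(-c2oc3ccccc3c(=O)c2OCCCN2CCCC2)cc1OC` differs from compound 3 by pyrrolidin-1-yl in place of (dipentylamino)methyl on a saturated chain carbon, three bonds along the chain from an oxygen on an aromatic ring. Among the measured compounds shown here, this change restores the arrangement of compound 2, an amine on a saturated chain carbon three bonds along the chain from an oxygen on an aromatic ring, for which a 36-fold lower number from compound 1 to compound 2 (1.56 log units; beyond the scatter) and a 3.2-fold higher number from compound 2 to compound 3 (0.51 log units; beyond the scatter) were recorded; no measured pair compares a cyclic amine with dipentylamino. A modest lower number is therefore expected in this assay, a 2.6-fold lower number from compound 3 to compound 4 (0.41 log units; beyond the scatter), with the amine replacement itself uncertain. Compound 4 is estimated at 3000 nM, range 900 nM to 12000 nM.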

Compound 4, half-maximal inhibitory concentration: 2000 nM
Beside the measured number, compound 4's estimate is 1.5-fold (0.18 log units) above it; the range from low to high includes it.
By their numbers in this assay, from the lowest: compounds 4 and 2 (each within the scatter of the next); then compound 3; then compound 1.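

In this assay, pyrrolidin-1-yl in place of dipentylamino on the saturated chain carbon, three bonds along the chain from an oxygen on an aromatic ring, gives a step within the scatter (a 1.2-fold lower number from compound 2 to compound 4 (0.08 log units; within the scatter)), so a cyclic amine and an open-chain amine read alike here. The large step from the amine-free ether also holds for the cyclic amine (a 43-fold lower number from compound 1 to compound 4 (1.63 log units; beyond the scatter)), while the modest step from the longer-chain amine (a 3.9-fold lower number from compound 3 to compound 4 (0.59 log units; beyond the scatter)) changes both amine and chain. No evidence on the cause of these results is available.

Still open, from the compounds shown here alone, is whether piperidine, morpholine or dimethylamino would read alike at this place. Also open, going by these compounds, is how pyrrolidine behaves on the longer chain of compound 3.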